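This account rests on a few compounds, and the source may have more. Where it says the series, first, only, none or still open, it means among the compounds named here.

Measured so far in a functional assay on NCI-H1975 cells (Homo sapiens) for inhibition, read by sulforhodamine B assay, tested at 10 uM; on this read-out lower numbers stand for less inhibition and higher numbers for more inhibition at the one concentration tested (going by the name of the read-out):
compound 1 `CN1CCN(c2ccc(C3=NN(S(=O)(=O)c4ccc(C#N)cc4)C(c4ccc(N(C)C)cc4)C3)cc2)CC1` — 100%
compound 2 `Cc1ccc(S(=O)(=O)N2N=C(c3ccc(-n4cncn4)cc3)CC2c2ccc(N(C)C)cc2)cc1` — 20%

Compound 2 stands lowest of the two numbers in this assay; its nearest neighbour is compound 1, which lies higher by a gap beyond the usual scatter. Compound 1 and compound 2 differ at more than one place, so their two values are set side by side without a single step between them.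

Compound 3 `CN(C)c1ccc(C2CC(c3ccc(-n4cncn4)cc3)=NN2S(=O)(=O)c2ccc(C#N)cc2)cc1` awaits measurement in this assay. It differs from compound 2 in one place: cyano in place of methyl on an aromatic carbon The sulfonyl substituent goes from (4-methylphenyl)sulfonyl to (4-cyanophenyl)sulfonyl. Compound 1, which carries the (4-cyanophenyl)sulfonyl group, gives 100% in this assay, but its second difference from compound 2 leaves the share of the cyano group unassigned. A step upward from compound 2 is expected, of the size a number 25 percentage points higher from compound 2 to compound 3 (beyond the scatter), larger than the scatter but well short of the gap to compound 1. Compound 3 is estimated at 45%, within a range from 20% to 75%.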

Compound 3, a percentage reported as inhibition, at one concentration (the size of the read-out at that concentration, not a potency): 22.6%
Estimate against measurement, compound 3: 22.4 percentage points above, within the range that was stated.
By their numbers in this assay, from the lowest: compounds 2 and 3 (each within the scatter of the next); then compound 1.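

In this assay, cyano in place of methyl on an aromatic carbon gives a number 2.6 percentage points higher from compound 2 to compound 3 (within the scatter) and so, with 1H-1,2,4-triazol-1-yl held constant, (4-cyanophenyl)sulfonyl and (4-methylphenyl)sulfonyl cannot be told apart at this position. With (4-cyanophenyl)sulfonyl held constant, 1H-1,2,4-triazol-1-yl in place of 4-methylpiperazin-1-yl on an aromatic carbon gives a number 77.4 percentage points lower from compound 1 to compound 3 (beyond the scatter) and is the only one of the two single changes that lies beyond the scatter. No measurement at hand bears on why either step has the size it does.

On these data alone, it remains open how (4-methylphenyl)sulfonyl reads alongside 4-methylpiperazin-1-yl, so the methyl-to-cyano change is known only with 1H-1,2,4-triazol-1-yl in the molecule. As far as these compounds go, it is also open which feature of 4-methylpiperazin-1-yl goes with the higher number, a question that an unsubstituted piperazine, a morpholine or an open-chain dimethylamino group at the same place could help to separate.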